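This account rests on a few compounds, and the source may have more. Where it says the series, first, only, none or still open, it means among the compounds named here.

Measured so far:
- compound 1 `CCOC(=O)c1cnn(-c2nc(-c3ccc(OC)cc3)c(C#N)c(=O)n2C)c1N` — 59 ug/mL
- compound 2 `CN(C)c1ccc(-c2nc(NN)n(C)c(=O)c2C#N)cc1` — 81 ug/mL
- compound 3 `Cn1c(NN)nc(-c2cccc(O)c2O)c(C#N)c1=O` — 34 ug/mL

In a functional assay, with a stated time of 20 min (on this read-out higher numbers stand for weaker inhibition and lower numbers for stronger inhibition), compound 1 gives 59 ug/mL, the second highest of the three numbers. The nearest to it is compound 2 with 81 ug/mL, and the furthest is compound 3 with 34 ug/mL; both gaps lie within the usual scatter, so no order among the three can be read from these numbers.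

Compound 4 `CCOC(=O)c1cnn(-c2nc(-c3cccs3)c(C#N)c(=O)n2C)c1N` is the next member. It differs from compound 1 by thiophen-2-yl in place of 4-methoxyphenyl on an aromatic carbon of the shared core. Among the compounds with values here, no pair of measured compounds shows this exchange, so nothing in the data fixes its size or direction. The three measured numbers all sit close together despite unrelated substituents at this position and elsewhere, and the expectation is therefore a step of no more than the scatter in either direction. Compound 4 is expected to give 55 ug/mL, with a range from 25 ug/mL to 120 ug/mL. The expected step is a 1.1-fold lower number from compound 1 to compound 4 (0.03 log units; within the scatter).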

Compound 4, half-maximal inhibitory concentration: 79 ug/mL
The estimate for compound 4 lay 1.4-fold (0.16 log units) below the measured number, within the range that was stated.
By their numbers in this assay, from the lowest: compounds 3, 1, 4 and 2 (each within the scatter of the next, the first and the last beyond it).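

In this assay, within the data shown here, thiophen-2-yl in place of 4-methoxyphenyl on this aromatic carbon of the shared core gives a 1.3-fold higher number from compound 1 to compound 4 (0.13 log units; within the scatter), the first exchange confined to one place. At this position, a five-membered aromatic ring with 1 hetero atom can therefore stand in for a six-membered aromatic ring of carbon only without a step beyond the scatter. No measurement at hand bears on the reason for this result.

As far as these compounds go, whether a non-aromatic amine such as morpholin-4-yl or a carboxylic acid on this carbon would also stay within the scatter remains open. Also open, from the compounds shown here alone, is whether the same exchange would give a similar step on a core other than that of compound 1.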